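Hydroxy-to-methoxy series: chloro for trifluoromethyl on the urea aryl

The compounds below may be only part of what the source reports. "The series", "measured", "known", "first", "only" and "open" are said of these compounds alone.

In a functional assay on MCF7 cells (Homo sapiens) for inhibition, read by sulforhodamine B assay, with a stated time of 48 h, tested at 100 uM (a lower number here means a stronger effect, a higher number a weaker effect of the compound at the concentration tested), compound 1 `O=C(Nc1cccc(-n2cc(-c3ccncc3)c(-c3cc(O)cc(Cl)c3)n2)c1)Nc1ccc(Cl)c(C(F)(F)F)c1` gives -43%, compound 2 `O=C(Nc1cccc(-n2cc(-c3ccncc3)c(-c3cc(O)cc(Cl)c3)n2)c1)Nc1ccc(Cl)c(Cl)c1` gives -2% and compound 3 `COc1cc(Cl)cc(-c2nn(-c3cccc(NC(=O)Nc4ccc(Cl)c(C(F)(F)F)c4)c3)cc2-c2ccncc2)c1` gives -8%. Compound 3 stands second highest of the three numbers; its nearest neighbour is compound 2, within the scatter, and its furthest is compound 1, beyond it. Two steps run from compound 1: a number 41 percentage points higher from compound 1 to compound 2 (beyond the scatter) and a number 35 percentage points higher from compound 1 to compound 3 (beyond the scatter).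

Compound 4 `COc1cc(Cl)cc(-c2nn(-c3cccc(NC(=O)Nc4ccc(Cl)c(Cl)c4)c3)cc2-c2ccncc2)c1` differs from compound 3 by chloro in place of trifluoromethyl on an aromatic carbon. The same change has already been measured once, on compound 1 to compound 2, where it gave a number 41 percentage points higher from compound 1 to compound 2 (beyond the scatter), a large step towards weaker effect. Applied to compound 3, which already sits near the weak end of the measured numbers, the same direction is expected, though the size is uncertain because -8% leaves less room for the number to climb than compound 1 had.

For compound 4 a step of a number 23 percentage points higher from compound 3 to compound 4 (beyond the scatter) is therefore expected in this assay, towards a weaker effect. The estimate for compound 4 is 15%, with a range from -12% to 42%.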

Compound 4, a percentage reported as activity, at one concentration (the size of the read-out at that concentration, not a potency): -13%
Compound 4: the middle estimate sits 28 percentage points above what was measured, and the stated range ends above it.
By their numbers in this assay, from the lowest: compound 1; then compounds 4, 3 and 2 (each within the scatter of the next, the first and the last beyond it).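

In this assay, with the methoxy group on the core, chloro in place of trifluoromethyl gives a number 5 percentage points lower from compound 3 to compound 4 (within the scatter), so the large shift towards weaker effect seen on the hydroxy core does not carry over: the same change on two cores in this assay, a number 41 percentage points higher (beyond the scatter) from compound 1 to compound 2 and a number 5 percentage points lower (within the scatter) from compound 3 to compound 4, 46 percentage points apart, beyond the scatter of two such steps

The methyl on the oxygen likewise depends on the urea aryl, since on the 3,4-dichlorophenyl compounds it gives a number 11 percentage points lower from compound 2 to compound 4 (beyond the scatter), which runs opposite to its step on the 4-chloro-3-(trifluoromethyl)phenyl compounds: the same change on two cores in this assay, a number 35 percentage points higher (beyond the scatter) from compound 1 to compound 3 and a number 11 percentage points lower (beyond the scatter) from compound 2 to compound 4, 46 percentage points apart, beyond the scatter of two such steps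

The two changes therefore do not act independently across these four compounds, and the strong reading of compound 1 at -43% appears only where the hydroxy and the trifluoromethyl occur together, with either single change moving the number well away from it.

Going by these compounds, whether that pairing needs a hydroxy in particular stays open, as an amine or a carboxylic acid at the same place would test it, and an ethoxy would show whether the methoxy reading extends to a longer chain. Bromo or methyl in place of the trifluoromethyl would show whether the hydroxy core responds only to trifluoromethyl at this position or also to other groups.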